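Carboxylic Acid Tail Gives Way to a Methyl Ether

A few compounds are considered here, and "the series" means these few. Any claim that something is new, unique, unknown or untested is made for them only; others in the source may bear on it.

Of the compounds shown here, three built on one shared core have been tested in a toxicity assay on A549 cells (Homo sapiens) for cytotoxicity, read by luminescence and CellTiter-Glo, with a stated time of 48 h; on this read-out lower numbers stand for higher toxicity in this test and higher numbers for lower toxicity in this test. Compound 1 `CCCCOc1ccc(-c2nc3ncccn3c2Nc2ccccc2)cc1` gives 100000 nM. Compound 2 `CCCCOc1ccc(-c2nc3ncccn3c2N2C(=O)c3cccc(O)c3C2=O)cc1` reaches only a limit of the assay, > 100000 nM. Compound 3 `O=C(O)CCCOc1ccc(-c2nc3ncccn3c2NC2CCCCC2)cc1` likewise reaches only a limit, > 100000 nM. Compound 3 therefore stands where the read-out stops rather than at a number, and the limit of > 100000 nM in this assay, at which 2 of the 3 values shown sit, marks the place where two of the three values sit. Among these three compounds nothing orders compound 3 above or below the others.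

Compound 4 `COCCCCOc1ccc(-c2nc3ncccn3c2NC2CCCCC2)cc1` has not yet been measured. Its difference from compound 3 is methoxymethyl in place of carboxy on a saturated chain carbon, three bonds along the chain from an oxygen on an aromatic ring. For the measured compounds named here, no measured pair of compounds shows a step of this kind, and no value among the three moves in a way that follows a change on the chain. The step from compound 3 to compound 4 is expected to stay within the scatter, a number no higher from compound 3 to compound 4 (the limit leaves the size open). Compound 4 is thus expected to give about 100000 nM in this assay, between 50000 nM and 200000 nM, and most likely again as a limit rather than a number.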

Compound 4, half-maximal cytotoxic concentration: 100000 nM
Beside the measured number, compound 4's estimate shows no gap at the digits printed, and the stated range covers the measured number.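

In this assay, compound 3 stands at a limit of the assay, > 100000 nM. Methoxymethyl in place of carboxy on a saturated chain carbon, three bonds along the chain from an oxygen on an aromatic ring, is the first change on this chain that can be followed between two measured compounds; it removes the hydrogen-bond donor of the carboxy and gives a number no higher from compound 3 to compound 4 (the limit leaves the size open), with compound 4 reading 100000 nM, so this tail change yields a real number where the acid gave none. The distance between the two stays unknown because the pair meets the end of the read-out: the limit of > 100000 nM in this assay, at which 2 of the 4 values shown sit.

With a single pair that differs in one place, the shown compounds cannot tell whether this chain position has any real influence on toxicity in this assay, or whether both tails simply leave the compounds close to the end of the measurable range. A chain ending in an amine or a hydroxyl, or a shorter or longer chain, would be needed to learn whether any group at this position can bring the value clearly lower.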